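A few compounds are considered here, and "the series" means these few. Any claim that something is new, unique, unknown or untested is made for them only; others in the source may bear on it.

Compound 3 `CC(C)=CCC/C(C)=C/CC1Cc2c(OCCCNC(=O)c3ccco3)cc(=O)n(CCCO)c2CC1(C)C` is measured in a functional assay on PANC-1 cells (Homo sapiens) for inhibition, read by MTT assay, with a stated time of 24 h, tested at 10 uM (on this read-out higher numbers stand for more inhibition at the one concentration tested (going by the name of the read-out) and lower numbers for less inhibition), where compound 3 gives 2.8%. Of the three measured compounds it stands second highest, with compound 1 `CC(C)=CCC/C(C)=C/COc1cc(=O)n(CCCO)c2c1CC(C/C=C(\C)CCC=C(C)C)C(C)(C)C2` giving 3.1% and compound 2 `CC(C)=CCC/C(C)=C/CC1Cc2c(OCCCNS(=O)(=O)c3ccc(Br)cc3)cc(=O)n(CCCO)c2CC1(C)C` giving 0%, and all three lie within the scatter of one another. Compound 4 `CC(C)=CCC/C(C)=C/CC1Cc2c(OCCCOc3ccc(Cl)cc3)cc(=O)n(CCCO)c2CC1(C)C` differs from compound 3 in one place: 4-chlorophenoxy in place of ((furan-2-yl)carbonyl)amino on a saturated chain carbon, three bonds along the chain from an oxygen on an aromatic ring. Two measured steps change the same part of the molecule: a number 0.3 percentage points lower from compound 1 to compound 3 (within the scatter) and a number 2.8 percentage points higher from compound 2 to compound 3 (within the scatter). Neither moved this assay beyond the scatter, so no step beyond the scatter is expected here either. Compound 4 is therefore expected to give about 3% in this assay, within a range from 0% to 12%. This amounts to an expected step of a number 0.2 percentage points higher from compound 3 to compound 4 (within the scatter).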

Compound 4, a percentage reported as inhibition, at one concentration (the size of the read-out at that concentration, not a potency): 0%
Compound 4: middle estimate off by 3 percentage points, on the high side; measured number inside the range.
By their numbers in this assay, from the lowest: compounds 2, 4, 3 and 1 (each within the scatter of the next).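

At the end of this chain, 4-chlorophenoxy, which has no hydrogen-bond donor, reads no differently in this assay from the two amide-type groups, with a number 2.8 percentage points lower from compound 3 to compound 4 (within the scatter) and no change at the digits printed from compound 2 to compound 4 (within the scatter) in that assay. Against the 2,6-dimethylhepta-1,5-dien-1-yl group of compound 1, the replacement gives a number 3.1 percentage points lower from compound 1 to compound 4 (within the scatter) on the same read-out, so all four compounds remain indistinguishable. No measurement shown offers an explanation for this flat picture. Still open, from the compounds shown here alone, is whether a primary amine, a carboxylic acid or a longer chain at this position would lift inhibition beyond the scatter.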